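Removing the tert-butyl group from compound 2

A few compounds are considered here, and "the series" means these few. Any claim that something is new, unique, unknown or untested is made for them only; others in the source may bear on it.

Values in a functional assay on HeLa cells (Homo sapiens) for inhibition, read by MTT assay, with a stated time of 72 h; a higher number here means a weaker inhibitor, a lower number a stronger inhibitor:
- compound 1 `Fc1ccc(-c2nnc(SCCCN3CCN(c4nc5ccccc5o4)CC3)o2)cc1`: 196000 nM
- compound 2 `CC(C)(C)Oc1ccc(-c2nnc(SCCCN3CCN(c4nc5ccccc5o4)CC3)o2)cc1`: 269000 nM

Only these two numbers exist so far, and compound 2 cannot be separated from compound 1 within the scatter.

Compound 3 `Oc1ccc(-c2nnc(SCCCN3CCN(c4nc5ccccc5o4)CC3)o2)cc1` is still unmeasured. Its difference from compound 2 is hydrogen in place of tert-butyl on an oxygen on an aromatic ring, or tert-butoxy to hydroxy.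

Among the compounds with values here, one measured step bears on this change: a 1.4-fold higher number from compound 1 to compound 2 (0.14 log units; within the scatter), with tert-butoxy in place of fluoro on an aromatic carbon. That step lies within the scatter. Within the data shown here, no measured compound carries hydroxy, so the evidence is indirect and gives no clear direction. No shift beyond the scatter is therefore expected in this assay. The expected change is a 1.2-fold lower number from compound 2 to compound 3 (0.09 log units; within the scatter) and it is estimated to stay within the scatter. For compound 3 the estimated value is 220000 nM, with an expected range from 90000 nM to 500000 nM.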

Compound 3, half-maximal inhibitory concentration: 99500 nM
Estimate against measurement, compound 3: 2.2-fold (0.34 log units) above; the measured number falls inside the stated range.
By their numbers in this assay, from the lowest: compounds 3, 1 and 2 (each within the scatter of the next, the first and the last beyond it).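

In this assay, within the data shown here, the group on the oxygen on the aromatic ring is the first place where a change clears the scatter: hydrogen in place of tert-butyl gives a 2.7-fold lower number from compound 2 to compound 3 (0.43 log units; beyond the scatter), a modest step that the earlier fluoro to tert-butoxy comparison gave no sign of. Hydroxy in place of fluoro gives a 2.0-fold lower number from compound 1 to compound 3 (0.29 log units; within the scatter), so these two groups cannot be told apart here, and the only readable difference in the series lies between tert-butoxy and hydroxy, with compound 1 within the scatter of both. Nothing measured alongside these numbers accounts for the step, which therefore stands as an observation only.

The three compounds cannot show whether the step depends on losing the whole tert-butyl group or on gaining the free hydroxy, and a methoxy group in the same place, or an amine or a carboxylic acid in place of the hydroxy, would separate those readings. All three also share the rest of the structure, so a shorter or longer chain in place of the one carrying the sulfur remains an open question.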